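The source may report more compounds than this note shows. Statements on the series, on what has been measured and on what is new or still open speak of the compounds shown alone.

Measured compounds in a functional assay on COLO 205 cells (Homo sapiens) for inhibition, read by MTT assay, with a stated time of 24 h; on this read-out higher numbers stand for weaker inhibition and lower numbers for stronger inhibition:
Compound 1 `[O-]/[N+](=C\c1cn(-c2ccccc2)nn1)c1ccccc1` gives > 100000 nM, which is a limit of the assay and not a number.
Compound 2 `[O-]/[N+](=C\c1cn(-c2ccc(F)cc2)nn1)c1ccccc1` gives 10200 nM.
Compound 3 `[O-]/[N+](=C\c1cn(-c2ccc(Cl)cc2)nn1)c1ccccc1` gives 9700 nM.

Compound 1 thus stands at the weak end of the three, sitting at the limit (the limit of > 100000 nM in this assay, at which 1 of the 3 values shown sits). The two measured steps, an at least 9.8-fold lower number from compound 1 to compound 2 (0.99 log units; beyond the scatter) and an at least 10-fold lower number from compound 1 to compound 3 (1.01 log units; beyond the scatter), both put a halogen on an aromatic carbon; the step of a 1.1-fold lower number from compound 2 to compound 3 (0.02 log units; within the scatter) is within the scatter. Compound 4 `CC(C)(C)/[N+]([O-])=C/c1cn(-c2ccccc2)nn1` differs from compound 1 by tert-butyl in place of phenyl on a double-bonded nitrogen. For the measured compounds named here, none of the measured steps touches that position, so they give no guide to the size or direction of the move in this assay, and for compound 1 only a limit is known as the starting point. Compound 4 is therefore expected to remain near the same limit, estimated at 100000 nM (range 30000 nM to 300000 nM), which means an expected step of a number no higher from compound 1 to compound 4 (the limit leaves the size open) not beyond the scatter.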

Compound 4, half-maximal inhibitory concentration: 15200 nM
For compound 4 the middle estimate is 6.6-fold (0.82 log units) above the measured one, outside the stated range (below it).
By their numbers in this assay, from the lowest: compounds 3, 2 and 4 (each within the scatter of the next). At a limit, above all of these: compound 1.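

In this assay, tert-butyl in place of phenyl on the double-bonded nitrogen gives an at least 6.5-fold lower number from compound 1 to compound 4 (0.81 log units; beyond the scatter), so this position, untouched by the halogen steps, also moves the read-out. A phenyl on this nitrogen is thus not needed for a measurable value in the series. The true size of the step stays unknown, since the value for compound 1 is a limit of the assay and not a number: the limit of > 100000 nM in this assay, at which 1 of the 4 values shown sits.

Open, as far as these compounds go, is whether tert-butyl on this nitrogen combines with the fluoro of compound 2 or the chloro of compound 3. Also open, from the compounds shown here alone, is how isopropyl or cyclohexyl would read at this nitrogen.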